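Swapping the ether group on the shared core

This account rests on a few compounds, and the source may have more. Where it says the series, first, only, none or still open, it means among the compounds named here.

Values in a physicochemical assay for solubility; a lower number here means a less soluble compound, a higher number a more soluble compound:
- compound 1 `CS(=O)(=O)c1ccc(-n2nc(C(F)(F)F)cc2NCC2CC2)nc1`: "not determined" (no result reported)
- compound 2 `CC(C)COc1cc(C(F)(F)F)nn1-c1ccc(S(C)(=O)=O)cn1`: 50 ug/mL
- compound 3 `CS(=O)(=O)c1ccc(-n2nc(C(F)(F)F)cc2OC2CCCC2)nc1`: 50 ug/mL

Compound 3 gives 50 ug/mL, level with compound 2 at 50 ug/mL. Compound 1 has no number to compare, so the picture rests on just these two values.

Next in line is compound 4 `CS(=O)(=O)c1ccc(-n2nc(C(F)(F)F)cc2OCC2CCC2)nc1`, not yet measured in this assay. It has the same atoms as compound 3, joined differently, with cyclobutylmethyl in place of cyclopentyl on an oxygen on an aromatic ring.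

Within the data shown here, only one measured step bears on this change: no change at the digits printed from compound 2 to compound 3 (within the scatter). That step also exchanges one all-carbon group on the oxygen for another, with cyclopentyl in place of isobutyl. It is thin evidence, but it gives no ground to expect a real shift in either direction. The expected move is no change at the digits printed from compound 3 to compound 4 (within the scatter), which is none beyond the scatter.

For compound 4 the estimated value is 50 ug/mL, with an expected range of 25 ug/mL to 100 ug/mL.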

Compound 4, solubility: 100 ug/mL
Compound 4: middle estimate off by 2.0-fold (0.30 log units), on the low side; the range from low to high includes it.
By their numbers in this assay, from the lowest: compounds 2, 3 and 4 (each within the scatter of the next).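

In this assay the change from cyclopentyloxy to cyclobutylmethoxy gives a 2.0-fold higher number from compound 3 to compound 4 (0.30 log units; within the scatter) at this position on the oxygen, so a four-membered ring held on a chain carbon reads the same as a five-membered ring on the oxygen itself. The comparison with the branched ether gives a 2.0-fold higher number from compound 2 to compound 4 (0.30 log units; within the scatter) for cyclobutyl in place of isopropyl on a saturated chain carbon bound to an oxygen on an aromatic ring, so isobutyl, cyclopentyl and cyclobutylmethyl are not separated by this read-out. No measurement in hand offers an explanation for these readings.

All the groups compared on this oxygen are made of carbon only. As far as these compounds go, whether a hydroxyl, an amine or a carboxylic acid on the group would give a step beyond the scatter remains open, as does the effect of a longer chain.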